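The source may hold more compounds than are shown below. What is called first, only, known or untested is meant among the compounds shown, and "the series" means these compounds.

Compound 1 `O=C(Nc1cc(Sc2ncn[nH]2)c(O)c2ccccc12)c1ccc([N+](=O)[O-])cc1` was tested in a functional assay on MDA-MB-231 cells (Homo sapiens) for antiproliferative activity, read by MTT assay, with a stated time of 48 h; a higher number here means a weaker inhibitor, a lower number a stronger inhibitor. Compound 1 gives > 100000 nM, which is a limit of this assay rather than a measured number. Compound 3 `O=C(Nc1cc(Sc2nncs2)c(O)c2ccccc12)c1ccc(Cl)cc1` likewise gives > 100000 nM, again only a limit. Compound 2 `COc1ccc(/C=C/C(=O)Nc2cc(Sc3ncn[nH]3)c(O)c3ccccc23)cc1OC` gives a numerical reading of 52500 nM. Compound 1 therefore stands at the limit of > 100000 nM in this assay, at which 2 of the 3 values shown sit, so the data place it among the weaker members of this small set, with compound 2 the only one of the three giving a number. Compound 4 `COc1cccc(C(=O)Nc2cc(Sc3ncn[nH]3)c(O)c3ccccc23)c1` has not yet been measured; it differs from compound 1 by 3-methoxyphenyl in place of 4-nitrophenyl on a carbonyl carbon. Within the data shown here, no measured pair shows this change, so the expected step is an at least 1.2-fold lower number from compound 1 to compound 4 (0.09 log units; that floor lies within the scatter), of no more than modest size in either direction. For compound 4 the estimate is 80000 nM, with a likely range from 30000 nM to 300000 nM.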

Compound 4, half-maximal inhibitory concentration: > 100000 nM
Compound 4 gave a limit, no number; the forecaster's own chance of this, stated with the estimate: 55%; at least 1.2-fold (0.09 log units) between middle value and limit.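

Among these compounds, compound 1 and compound 4 each give only a limit in this assay, not a number, so no step between them can be read. The compounds shown leave open whether 3-methoxyphenyl in place of 4-nitrophenyl on a carbonyl carbon changes the result at all.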